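Swapping Methyl for Methoxy on Compound 3

The source may hold more compounds than are shown below. What is called first, only, known or untested is meant among the compounds shown, and "the series" means these compounds.

Three measured compounds share one core and differ only in the group on a saturated chain carbon bound to a carbonyl carbon and an oxygen. In a functional assay on a cell-free system (plasma, Homo sapiens), with a stated time of 3 min (on this read-out higher numbers stand for weaker inhibition and lower numbers for stronger inhibition), compound 1 `CC1(C[C@@H](O)C(=O)N2C[C@H]3C[C@H]3[C@H]2C(=O)NCc2cc(Cl)ccc2-n2cnnn2)CC1` gives 500 nM, compound 2 `O=C(NCc1cc(Cl)ccc1-n1cnnn1)[C@@H]1[C@@H]2C[C@@H]2CN1C(=O)[C@H](O)c1ccccc1F` gives 580 nM, and compound 3 `CC(C)(C)[C@@H](O)C(=O)N1C[C@H]2C[C@H]2[C@H]1C(=O)NCc1cc(Cl)ccc1-n1cnnn1` gives 1200 nM, the highest number of the three and thus the weakest inhibition here. The steps of a 2.4-fold higher number from compound 1 to compound 3 (0.38 log units; beyond the scatter) and a 2.1-fold higher number from compound 2 to compound 3 (0.32 log units; beyond the scatter) show that changes at this group shift the read-out, though only modestly. Compound 4 `COC(C)(C)[C@@H](O)C(=O)N1C[C@H]2C[C@H]2[C@H]1C(=O)NCc1cc(Cl)ccc1-n1cnnn1` makes a smaller change: methoxy in place of methyl on a saturated chain carbon bound to three saturated chain carbons. Going by the values given here, no measured step exchanges methyl for methoxy, and the steps that do exist are modest, so no step beyond the scatter is expected in this assay. Compound 4 is expected to give 1000 nM, between 450 nM and 2500 nM. The expected step of a 1.2-fold lower number from compound 3 to compound 4 (0.08 log units; within the scatter) stays within the scatter.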

Compound 4, half-maximal inhibitory concentration: 1000 nM
For compound 4 middle estimate and measured number coincide at the digits printed, and the stated range covers the measured number.
By their numbers in this assay, from the lowest: compounds 1, 2, 4 and 3 (each within the scatter of the next, the first and the last beyond it).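

In this assay the swap of methyl for methoxy gives a 1.2-fold lower number from compound 3 to compound 4 (0.08 log units; within the scatter) and so leaves the read-out essentially unchanged at this place. Compound 4 also stays within the scatter of the other two compounds, with a 1.7-fold higher number from compound 2 to compound 4 (0.24 log units; within the scatter) and a 2.0-fold higher number from compound 1 to compound 4 (0.30 log units; within the scatter), whereas compound 3 lies beyond the scatter from both. Nothing available gives a reason for this result. Still open, on these data alone, is whether a hydroxy group, an amine or a carboxylic acid in place of that methyl would move the number beyond the scatter.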